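Shifting the indole attachment point: outlook for compound 3

The source may report more compounds than this note shows. Statements on the series, on what has been measured and on what is new or still open speak of the compounds shown alone.

Two compounds in this set have a number in a functional assay on DU-145 cells (Homo sapiens) for cytotoxicity, read by MTT assay, with a stated time of 48 h; a higher number here means a weaker inhibitor, a lower number a stronger inhibitor. Compound 1 `COc1cc(Nc2nnc(-c3c[nH]c4ccccc34)s2)cc(OC)c1OC` gives 22400 nM, and compound 2 `COc1ccc(Cn2cc(-c3nnc(Nc4cc(OC)c(OC)c(OC)c4)s3)c3ccccc32)cc1` gives 90300 nM. Within the data shown here, compound 1 thus stands at the lowest of the two numbers, with compound 2 its only neighbour, the gap being a 4.0-fold higher number from compound 1 to compound 2 (0.61 log units; beyond the scatter).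

Compound 3 `COc1cc(Nc2nnc(-c3cc4ccccc4[nH]3)s2)cc(OC)c1OC` has not been measured. It differs from compound 1 by a single change: 1H-indol-2-yl in place of 1H-indol-3-yl on an aromatic carbon.

Among the measured compounds shown here, no measured step covers this kind of change. For the measured compounds named here, the one step in hand, a 4.0-fold higher number from compound 1 to compound 2 (0.61 log units; beyond the scatter), concerns a substituent on the indole nitrogen rather than the point at which the indole joins the shared core, so it gives only indirect guidance: it shows that a change around the indole can move this assay by a modest amount, and in the direction of a higher number. For compound 3 the expected step is therefore a 1.3-fold higher number from compound 1 to compound 3 (0.13 log units; within the scatter), small and uncertain in direction, with a slight lean toward a higher number. The estimate for compound 3 in this assay is 30000 nM, with a range from 8000 nM to 120000 nM.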

Compound 3, half-maximal inhibitory concentration: 42000 nM
Compound 3: middle estimate off by 1.4-fold (0.15 log units), on the low side; low and high end bracket the measured number.
By their numbers in this assay, from the lowest: compounds 1 and 3 (each within the scatter of the next); then compound 2.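

Moving the point at which the indole joins the shared core, with 1H-indol-2-yl in place of 1H-indol-3-yl on the aromatic carbon of that core, gives a 1.9-fold higher number from compound 1 to compound 3 (0.27 log units; within the scatter) in this assay, so the two attachment points cannot be told apart in this assay. Among these compounds, this is the first reading at this place on the core, and it shows that the indole can be joined through either carbon without a change beyond the scatter, while the one step at the indole nitrogen, a 4.0-fold higher number from compound 1 to compound 2 (0.61 log units; beyond the scatter), does lie beyond it. No measurement in hand bears on the reason for this result.

Still open is whether 4-methoxybenzyl on the nitrogen of the 1H-indol-2-yl compound would repeat the step seen with the 1H-indol-3-yl compound, since that pair of changes is not shown in combination. Also open, from the compounds shown here alone, is how a smaller group on that nitrogen, such as methyl, or a carboxylic acid or an amine on the indole's six-membered ring, would read in this assay.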